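Swapping bromo for methyl on compound 3

The compounds below may be only part of what the source reports. "The series", "measured", "known", "first", "only" and "open" are said of these compounds alone.

In an ADME assay on S9 fraction from S9 cells (Zone of skin, Homo sapiens) for metabolic stability, read by HPLC, with a stated time of 180 min, tested at 0.5 uM (on this read-out higher numbers stand for a longer-lived compound and lower numbers for a shorter-lived compound), compound 3 `CCC/N=C1\S/C(=C\c2ccc(OC(C)=O)c(Br)c2)C(=O)N1c1ccccc1C` gives 0.147 h as the lowest number measured, and compound 2 `CCC/N=C1\S/C(=C\c2ccc(OC(=O)C(C)C)c(C)c2)C(=O)N1c1ccccc1C` with 0.35 h sits above it. Compound 1 `CCC/N=C1\S/C(=C\c2ccc(OC(=O)C(C)(C)C)c(C)c2)C(=O)N1c1ccccc1C` reports > 3 h as a limit only. Compared with compound 3, compound 4 `CCC/N=C1\S/C(=C\c2ccc(OC(C)=O)c(C)c2)C(=O)N1c1ccccc1C` carries methyl in place of bromo on an aromatic carbon and nothing else differs. Going by the values given here, the one measured step of an at least 8.5-fold lower number from compound 1 to compound 2 (0.93 log units; beyond the scatter) lies elsewhere, on a saturated chain carbon bound to a carbonyl carbon, so it sets no size for this swap. Compound 3 at 0.147 h shares its acetoxy group with compound 4, so no step beyond the scatter is expected in this assay here. The expected step of a 1.1-fold higher number from compound 3 to compound 4 (0.04 log units; within the scatter) stays within the scatter. Compound 4 is estimated at 0.16 h with 0.07 h to 0.35 h as the expected range.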

Compound 4, half-life: 0.122 h
Compound 4: middle estimate off by 1.3-fold (0.12 log units), on the high side, within the range that was stated.
By their numbers in this assay, from the lowest: compounds 4 and 3 (each within the scatter of the next); then compound 2. At a limit, above all of these: compound 1.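

In this assay, bromo and methyl ortho to the acetoxy group cannot be told apart, since the step is a 1.2-fold lower number from compound 3 to compound 4 (0.08 log units; within the scatter). With methyl on that aromatic carbon throughout, the group on the carbonyl carbon now sets the size of the change, with a 2.9-fold lower number from compound 2 to compound 4 (0.46 log units; beyond the scatter) and an at least 24-fold lower number from compound 1 to compound 4 (1.39 log units; beyond the scatter). The number for compound 1 is a limit only: the limit of > 3 h in this assay, at which 1 of the 4 values shown sits.

Still open, on these data alone, is whether methoxy or chloro on this aromatic carbon would also stay within the scatter. Also open, as far as these compounds go, is whether bromo and methyl would remain indistinguishable with isopropyl or tert-butyl on the carbonyl carbon.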